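From Compound 1 to Compound 4: Adding a Side Chain

The source may report more compounds than this note shows. Statements on the series, on what has been measured and on what is new or still open speak of the compounds shown alone.

Compound 1 `Cn1c(N)c(-c2nc3ccccc3[nH]2)c2nc(C#N)c(C#N)nc21` was tested for its ability to stop cancer cells from growing in a functional assay on HeLa cells (Homo sapiens) for antiproliferative activity, read by MTT assay, with a stated time of 48 h; a higher number here means a weaker inhibitor, a lower number a stronger inhibitor. Compound 1 gives > 50000 nM, which is a limit and not a number. Compound 2 `CCn1c(N)c(-c2nc3ccccc3[nH]2)c2nc(C#N)c(C#N)nc21` gives > 50000 nM, which is also a limit. Compound 3 `N#Cc1nc2c(-c3nc4ccccc4[nH]3)c(N)n(CCCN3CCCCC3)c2nc1C#N` gives a true number, and compound 3 reads 6680 nM.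

Compound 4 `CN(C)CCCCn1c(-c2c(N)n(C)c3nc(C#N)c(C#N)nc23)nc2ccccc21` keeps the methyl of compound 1 and gains a new chain: 4-(dimethylamino)butyl in place of hydrogen on an aromatic nitrogen. In words, 4-(dimethylamino)butyl replaces hydrogen on an aromatic nitrogen.

Within the data shown here, three measured steps bear on this change. The small extension gives a step that the two limits leave unreadable from compound 1 to compound 2, so it offers no guidance. The larger chain ending in piperidine gives an at least 7.4-fold lower number from compound 1 to compound 3 (0.87 log units; beyond the scatter), and the same compound also shows an at least 7.4-fold lower number from compound 2 to compound 3 (0.87 log units; beyond the scatter). Among the measured compounds shown here, compound 3 is therefore the only precedent for a long, nitrogen-bearing chain helping, but its chain sits at a different place from the new one in compound 4. A lower number is expected in this assay, with a size similar to that seen for compound 3, though with real uncertainty. The estimated step is an at least 5.5-fold lower number from compound 1 to compound 4 (0.74 log units; beyond the scatter). For compound 4, the expected value is 9000 nM, with an estimated range of 2500 nM to 40000 nM.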

Compound 4, half-maximal inhibitory concentration: 10100 nM
Beside the measured number, compound 4's estimate is 1.1-fold (0.05 log units) below it; the range from low to high includes it.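

In this assay, 4-(dimethylamino)butyl in place of hydrogen on an aromatic nitrogen gives an at least 4.9-fold lower number from compound 1 to compound 4 (0.69 log units; beyond the scatter), so this nitrogen of the five-membered aromatic ring with 2 nitrogen can carry a long chain and still give a stronger inhibitor. Before this, the only readable gain came from the chain ending in piperidine on compound 3, which stands at a different place on the shared core, so a second place that rewards a chain bearing an amine has now appeared. The full size of the step stays unknown because compound 1 gives only a limit of the assay, not a number: the limit of > 50000 nM in this assay, at which 2 of the 4 values shown sit.

What the compounds shown leave open is whether the gain at this nitrogen needs the dimethylamino group at all, or would also come from a plain butyl chain, a shorter chain such as 2-(dimethylamino)ethyl, or a chain ending in piperidine. Also open, on these data alone, is whether a chain ending in an amine at each of the two places together would lower the number further than either chain alone.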